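The source may hold more compounds than are shown below. What is called first, only, known or untested is meant among the compounds shown, and "the series" means these compounds.

Compound 1, `CCN(Cc1ccncc1)C(=S)SCc1ccc(C(=O)Nc2ccccc2N)cc1`, is the reference point of this set. In a functional assay on HeLa cells (Homo sapiens) for antiproliferative activity, read by CCK-8 assay, with a stated time of 72 h, tested at 8 uM (a higher number here means a stronger effect of the compound at the concentration tested, a lower number a weaker effect), compound 1 gives 77.7%, the highest of the three numbers recorded. Compound 3, `Nc1ccccc1NC(=O)c1ccc(CSC(=S)N2CCN(Cc3ccncc3)CC2)cc1`, gives 72.9% in this assay, a value within the scatter of compound 1, so the two cannot be ordered. Compound 2, `Nc1ccccc1NC(=O)c1ccc(CSC(=S)N2CCc3ccc([N+](=O)[O-])cc32)cc1`, gives 62.1% in this assay, a number beyond the scatter below compound 1 and the only result in the set that clearly separates from the reference.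

Compound 4, `Nc1ccccc1NC(=O)c1ccc(CSC(=S)N2CCCc3ccccc32)cc1`, has not yet been measured. It differs from compound 1 in one place: 1,2,3,4-tetrahydroquinolin-1-yl in place of ethyl((pyridin-4-yl)methyl)amino on a thiocarbonyl carbon. The amine attached to the thiocarbonyl carbon is thus no longer an open ethyl((pyridin-4-yl)methyl)amino group but the fused 1,2,3,4-tetrahydroquinolin-1-yl ring, which carries no hydrogen-bond acceptor where the pyridine of compound 1 had one.

Among the measured compounds shown here, no direct step between two measured compounds matches this change, so any expectation rests on what the three numbers show. Compound 2 carries a fused bicyclic amine at the same place and gives 62.1%, lower than compound 1, so a downward step is expected. The step from compound 1 to compound 4 is estimated as a number 11.7 percentage points lower from compound 1 to compound 4 (beyond the scatter), modest and near the edge of the scatter. Compound 4 is therefore expected to give about 66% in this assay, with a range from 48% to 80%.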

Compound 4, a percentage reported as inhibition, at one concentration (the size of the read-out at that concentration, not a potency): 35.7%
Estimate against measurement, compound 4: 30.3 percentage points above; measured number below the stated range.
By their numbers in this assay, from the lowest: compound 4; then compound 2; then compounds 3 and 1 (each within the scatter of the next).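

Among the compounds shown here, the change of amine on the thiocarbonyl carbon has a much larger effect in this assay than the earlier compounds could show: 1,2,3,4-tetrahydroquinolin-1-yl in place of ethyl((pyridin-4-yl)methyl)amino gives a number 42 percentage points lower from compound 1 to compound 4 (beyond the scatter). The leaving and entering groups have equal heavy-atom counts and neither has a hydrogen-bond donor, so this large step occurs without a difference in those counts, while the entering group has no hydrogen-bond acceptor and its aromatic ring is carbon only. No measurement in hand gives a reason for the step.

The compounds shown leave open which difference carries the step, the loss of the pyridine nitrogen or the closing of the open amine into a fused ring system. An open benzyl(ethyl)amino group or a piperidine on the same thiocarbonyl carbon would bear on that question, and the read-out, taken at one concentration, remains a size of effect at that concentration and not a potency.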